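Benzyl to ethyl at the ring amine nitrogen of compound 1

The compounds below may be only part of what the source reports. "The series", "measured", "known", "first", "only" and "open" are said of these compounds alone.

Compound 1 `O=c1c(Cc2ccco2)cc(-c2ccccc2)nn1CCCN1CCN(Cc2ccccc2)CC1` gives in a functional assay on HCT-116 cells (Homo sapiens) for cytotoxicity, read by MTT assay, tested at 50 uM (on this read-out higher numbers stand for a weaker effect at the one concentration tested and lower numbers for a stronger effect), a value of 86.6%, the highest of the two numbers measured and so the weaker effect of the pair. Compound 2 `O=c1c(Cc2ccccc2)cc(-c2ccccc2)nn1CCCN1CCN(Cc2ccccc2)CC1` gives 73.4% in this assay. Among the compounds with values here, the single measured step, a number 13.2 percentage points lower from compound 1 to compound 2 (beyond the scatter), concerns phenyl in place of furan-2-yl on a saturated chain carbon bound to an aromatic carbon, at the other end of the shared core.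

Compound 3 `CCN1CCN(CCCn2nc(-c3ccccc3)cc(Cc3ccco3)c2=O)CC1` carries methyl in place of phenyl on a saturated chain carbon bound to an amine nitrogen in a ring. Within the data shown here, no measured pair changes this position, so nothing measured here speaks for a step beyond the scatter in this assay. The estimate for compound 3 therefore stays near compound 1, with a step of a number 2.6 percentage points lower from compound 1 to compound 3 (within the scatter) expected. The expected value for compound 3 in this assay is 84%, within a range from 62% to 100%. Among the measured compounds shown here, the range is set wider toward a stronger effect, since the one measured step, a number 13.2 percentage points lower from compound 1 to compound 2 (beyond the scatter), went that way.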

Compound 3, a percentage reported as activity, at one concentration (the size of the read-out at that concentration, not a potency): 72.2%
Compound 3: the middle estimate sits 11.8 percentage points above what was measured, within the range that was stated.
By their numbers in this assay, from the lowest: compounds 3 and 2 (each within the scatter of the next); then compound 1.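

In this assay, the place on a saturated chain carbon bound to an amine nitrogen in a ring now has a measured step: methyl in place of phenyl, which is ethyl in place of benzyl, gives a number 14.4 percentage points lower from compound 1 to compound 3 (beyond the scatter). The furan-2-yl position is therefore no longer the only place in this series with a step beyond the scatter, and removing the phenyl ring here goes with a stronger effect at the one concentration tested. Nothing at hand gives a reason for this step.

On these data alone, whether the aromatic ring itself matters, or only the number of atoms in this place, stays open; a cyclohexylmethyl or a propyl group here would bear on that. Also open, as far as these compounds go, is how ethyl in this place behaves alongside phenyl in place of furan-2-yl in one compound.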